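From Hydrogen to Sec-Butoxy: An Open Question

A few compounds are considered here, and "the series" means these few. Any claim that something is new, unique, unknown or untested is made for them only; others in the source may bear on it.

Among the measured compounds shown here, compound 1 `O=C(O)c1cnc(-c2ccccc2)[nH]c1=O` is the one compound here with a number of its own: in a functional assay on the whole organism (strain Sprague-Dawley) for inhibition, with Rattus norvegicus as the target, with a stated time of 10 min (on this read-out higher numbers stand for an effect only at larger amounts of compound and lower numbers for an effect already at smaller amounts), compound 1 gives 50 mg/kg. Its partner compound 2 `O=C(O)c1cnc(-c2ccccc2[N+](=O)[O-])[nH]c1=O` carries a nitro in place of hydrogen on an aromatic carbon. In this assay compound 2 reaches only a limit, > 50 mg/kg, and no number is known for it. The step of a number no lower from compound 1 to compound 2 (the limit leaves the size open) therefore has no readable size; all that can be said is that compound 2 was not more effective than compound 1, and this rests on (the limit of > 50 mg/kg in this assay, at which 1 of the 2 values shown sits).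

Compound 3 `CCC(C)Oc1ccccc1-c1ncc(C(=O)O)c(=O)[nH]1` differs from compound 1 by sec-butoxy in place of hydrogen on an aromatic carbon. For the measured compounds named here, no measured step concerns a sec-butoxy group, and the one step measured, the nitro one, left its size open, which gives no firm direction for compound 3 in this assay. The number for compound 3 is estimated to stay near that of compound 1, with the expected step of no change at the digits printed from compound 1 to compound 3 (within the scatter) lying within the scatter. Compound 3 is thus estimated at 50 mg/kg, within a range from 15 mg/kg to 150 mg/kg, with a real chance that this assay again reports only a limit.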

Compound 3, dose for 50% inhibition: 0.5 mg/kg
The estimate for compound 3 lay 100-fold (2.00 log units) above the measured number, and the stated range ends above it.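

In this assay, the carbon that carries sec-butoxy in compound 3, ortho to a large group, turns out to be a place where a single change can have a large effect on the dose needed: the exchange of hydrogen for sec-butoxy gives a 100-fold lower number from compound 1 to compound 3 (2.00 log units; beyond the scatter). The nitro compound had shown no gain at this carbon, whereas the exchange of nitro for sec-butoxy gives an at least 100-fold lower number from compound 2 to compound 3 (2.00 log units; beyond the scatter), so what matters is which group sits there, not merely that the hydrogen has been replaced. The value of compound 2 is a limit and not a number: the limit of > 50 mg/kg in this assay, at which 1 of the 3 values shown sits.

The compounds shown leave open whether the large step belongs to the oxygen joined to the aromatic ring or to the branched chain attached to that oxygen, and they give no measured property that could explain it. Methoxy, a longer straight alkoxy chain or an amine on this same carbon would each offer a one-place comparison with compound 3 and could begin to separate those two parts of the sec-butoxy group.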